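The source may hold more compounds than are shown below. What is called first, only, known or untested is meant among the compounds shown, and "the series" means these compounds.

Working notes on the series, values in an ADME assay on SW1353 cells (Homo sapiens) for cytotoxicity, read by a luciferase reporter, with a stated time of 30 min; a lower number here means that less compound is tolerated, a higher number that more compound is tolerated:

- Compound 1 `O=C(Nc1ccc(N2CCNCC2)cc1)c1ccc(-c2ccc(Cl)s2)o1`: > 20000 nM
- Compound 2 `O=C(Nc1ccc(N2CCNCC2)cc1)c1cccc(-c2ccc(Cl)cc2)n1`: > 10000 nM
- Compound 3 `CN(C(=O)c1ccc(-c2ccc(Cl)cc2)o1)c1ccc(N2CCNCC2)cc1`: > 20000 nM

All three entries are limits and not numbers. Compound 3 stands at > 20000 nM, which is a limit. That entry belongs to the limit of > 20000 nM in this assay, at which 2 of the 3 values shown sit. The remaining entry belongs to the limit of > 10000 nM in this assay, at which 1 of the 3 values shown sits. The series therefore gives no numerical rank order.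

The next compound is compound 4 `O=C(c1ccc(-c2ccc(Cl)cc2)o1)N(Cc1ccncc1)c1ccc(N2CCNCC2)cc1`. Its difference from compound 3 is pyridin-4-yl in place of hydrogen on a saturated chain carbon bound to an amide-type nitrogen. Cut one bond further out, the same difference reads methyl to (pyridin-4-yl)methyl.

For the measured compounds named here, no measured step in this assay is available for this change or for any other. The expectation rests only on the limits of the three measured compounds, and no step beyond the scatter is expected. The expected change is an at least 1.1-fold lower number from compound 3 to compound 4 (0.04 log units; that floor lies within the scatter). A limit is again a likely outcome for compound 4. For compound 4 the estimated value is 18000 nM, with an expected range of 7000 nM to 30000 nM.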

Compound 4, half-maximal cytotoxic concentration: > 8000 nM
Compound 4: no number, only a limit; the forecaster's own chance of this, stated with the estimate: 70%; the middle value lies beyond the limit too.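

In this assay compound 4 gives > 8000 nM, which is a limit. Compound 3 also carries a limit, so no step can be read between compound 3 and compound 4. The compounds shown leave open whether pyridin-4-yl in place of hydrogen changes the half-maximal cytotoxic concentration at all.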